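Working notes: from compound 2 to compound 3

The compounds below may be only part of what the source reports. "The series", "measured", "known", "first", "only" and "open" are said of these compounds alone.

For the measured compounds named here, in a functional assay, read by spectrophotometry (a lower number here means that less compound is needed, a higher number that more compound is needed for the effect), compound 1 (`COc1ccc(-c2cc(=O)c3ccc(OCCCN4CCC(C)CC4)cc3o2)cc1`) gives 26.6 nM and compound 2 (`COc1ccc(-c2cc(=O)c3ccc(OCCCN4CCC(CCO)CC4)cc3o2)cc1`) gives 22.8 nM, so compound 2 stands level with the only other number available. Next in line is compound 3 (`COc1ccc(-c2cc(=O)c3ccc(OCCCCN4CCC(C)CC4)cc3o2)cc1`). The change is (4-methylpiperidin-1-yl)methyl in place of 4-(2-hydroxyethyl)piperidin-1-yl on a saturated chain carbon, three bonds along the chain from an oxygen on an aromatic ring. Going by the values given here, one measured step bears on this: a 1.2-fold lower number from compound 1 to compound 2 (0.07 log units; within the scatter), which stays within the scatter and covers only the substituent on the piperidine. Among the compounds with values here, no measured step shows what the rest of the change does, so the expectation is uncertain. No shift beyond the scatter is expected in this assay. The expected step is a 1.3-fold higher number from compound 2 to compound 3 (0.12 log units; within the scatter). For compound 3 the estimated value is 30 nM, with an expected range of 10 nM to 90 nM.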

Compound 3, half-maximal effective concentration: 28.1 nM
For compound 3 the middle estimate is 1.1-fold (0.03 log units) above the measured one; the measured number falls inside the stated range.
By their numbers in this assay, from the lowest: compounds 2, 1 and 3 (each within the scatter of the next).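

In this assay, (4-methylpiperidin-1-yl)methyl in place of 4-methylpiperidin-1-yl on a saturated chain carbon, three bonds along the chain from an oxygen on an aromatic ring, gives a 1.1-fold higher number from compound 1 to compound 3 (0.02 log units; within the scatter), so this position, untouched by the earlier pair, can take the extended chain without leaving the scatter. The wider exchange, (4-methylpiperidin-1-yl)methyl in place of 4-(2-hydroxyethyl)piperidin-1-yl, gives a 1.2-fold higher number from compound 2 to compound 3 (0.09 log units; within the scatter), and all three numbers stand level so far.

Open, on these data alone, is whether the level reading holds for a still longer chain, or for a carboxylic acid or a primary amine on the piperidine. Also open, as far as these compounds go, is how 4-(2-hydroxyethyl)piperidin-1-yl reads on the extended chain. Nothing at hand offers a reason for these level numbers.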